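A few compounds are considered here, and "the series" means these few. Any claim that something is new, unique, unknown or untested is made for them only; others in the source may bear on it.

Compound 1 `O=Cc1ccc(-c2cn3ccnc3c(-c3ccc4ncn(C5CCCCC5)c4c3)n2)cc1` and compound 2 `c1ccc2c(-c3cn4ccnc4c(-c4ccc5ncn(C6CCCCC6)c5c4)n3)cccc2c1` share one core and differ only in the aromatic group attached at a single carbon of that core. In a functional assay on HL-60 cells (Homo sapiens) for inhibition, read by sulforhodamine B assay, with a stated time of 48 h, tested at 10 uM (on this read-out higher numbers stand for more inhibition at the one concentration tested (going by the name of the read-out) and lower numbers for less inhibition), compound 1 gives 16.5%, while compound 2 gives 38.9%. Compound 2 stands highest of the two numbers, and its nearest neighbour is compound 1, the measured step being a number 22.4 percentage points higher from compound 1 to compound 2 (beyond the scatter). Compound 3 `CC(=O)c1ccc(-c2cn3ccnc3c(-c3ccc4ncn(C5CCCCC5)c4c3)n2)cc1` has not yet been measured. It differs from compound 2 in one place: 4-acetylphenyl in place of naphthalen-1-yl on an aromatic carbon. For the measured compounds named here, the single measured step bears directly on this change, because a number 22.4 percentage points higher from compound 1 to compound 2 (beyond the scatter) describes the reverse move, a 4-formylphenyl group giving way to naphthalen-1-yl, and 4-acetylphenyl is a close relative of 4-formylphenyl. A drop of roughly that size is therefore expected in this assay. Compound 3 is expected to give 20%, within a range of 5% to 38%. That estimate corresponds to an expected step of a number 18.9 percentage points lower from compound 2 to compound 3 (beyond the scatter).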

Compound 3, a percentage reported as inhibition, at one concentration (the size of the read-out at that concentration, not a potency): 2.65%
For compound 3 the middle estimate is 17.4 percentage points above the measured one; measured number below the stated range.
By their numbers in this assay, from the lowest: compound 3; then compound 1; then compound 2.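

In this assay, the swap to 4-acetylphenyl from naphthalen-1-yl gives a number 36.3 percentage points lower from compound 2 to compound 3 (beyond the scatter) and so confirms that this position responds strongly to the group placed on it. The earlier pair could not show that a much smaller edit also matters here, yet a methyl in place of hydrogen on the carbonyl carbon gives a number 13.9 percentage points lower from compound 1 to compound 3 (beyond the scatter) in the same assay. No measurement is at hand that explains either drop.

Going by these compounds, whether a longer chain on that carbonyl carbon would lower the number further remains open. So does whether an amine or a carboxylic acid on the phenyl ring, in place of the acetyl group, would bring it back towards the level of compound 2.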